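Methylsulfanyl in place of ethoxy: an oral bioavailability estimate

The source may report more compounds than this note shows. Statements on the series, on what has been measured and on what is new or still open speak of the compounds shown alone.

Two compounds of the series have numbers in an ADME assay on the whole organism (Mus musculus, strain CD-1) for pharmacokinetics, at a dose of 10 mg/kg by the oral route; on this read-out higher numbers stand for higher oral bioavailability and lower numbers for lower oral bioavailability. Compound 1 `CCOc1cc([C@](O)(CCN(C)C)[C@@H](c2cc3cc(Br)ccc3nc2OC)c2cccc(OC)c2F)cc(OC)n1` gives 46% in this assay. Compound 2 `CCOc1cc([C@](O)(CCN(C)C)[C@H](c2cccc(C)c2)c2cc3cc(Br)ccc3nc2OC)cc(OC)n1` gives 65% in this assay. Going by the values given here, of the two numbers, compound 1 stands lowest; its only neighbour is compound 2, reached by the step of a number 19 percentage points higher from compound 1 to compound 2 (beyond the scatter), which comes from 3-methylphenyl in place of 2-fluoro-3-methoxyphenyl on a saturated chain carbon bound to an aromatic carbon and a saturated chain carbon.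

Compound 3 `COc1cc([C@](O)(CCN(C)C)[C@@H](c2cc3cc(Br)ccc3nc2OC)c2cccc(OC)c2F)cc(SC)n1` awaits measurement. Against compound 1 the difference is methylsulfanyl in place of ethoxy on an aromatic carbon The site is an aromatic carbon of a six-membered aromatic ring with 1 nitrogen, next to the ring nitrogen, meta to a large group and meta to a methoxy group.

Among the compounds with values here, no measured step touches this ring position. Within the data shown here, the single measured step, a number 19 percentage points higher from compound 1 to compound 2 (beyond the scatter), alters another part of the molecule and is no guide to an ethoxy-to-methylsulfanyl swap. For compound 3 the expected step is no change at the digits printed from compound 1 to compound 3 (within the scatter), within the scatter. Compound 3 is therefore estimated at 46%, with a range from 25% to 66%.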

Compound 3, oral bioavailability: 31%
Beside the measured number, compound 3's estimate is 15 percentage points above it; measured number inside the range.
By their numbers in this assay, from the lowest: compound 3; then compound 1; then compound 2.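

Going by these compounds alone, the ring position next to the ring nitrogen responds in this assay, which the earlier pair could not show, since its only step lay at the aryl group on the saturated chain carbon. Here the exchange gives a number 15 percentage points lower from compound 1 to compound 3 (beyond the scatter), so methylsulfanyl in place of ethoxy is a change that registers beyond the scatter, and a second site in the series now moves this read-out, in the downward direction. The exchange alters two things at once, putting sulfur where oxygen stood and going from three heavy atoms to two, and this single step does not separate them.

Still open, from the compounds shown here alone, is whether the sulfur or the shorter group carries the step, which an ethylsulfanyl group or a propoxy chain at this place would address, and whether the step holds with the 3-methylphenyl group of compound 2 in place of the 2-fluoro-3-methoxyphenyl group of compound 1. The data at hand offer no measurement that accounts for the lower oral exposure seen with this exchange.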